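A few compounds are considered here, and "the series" means these few. Any claim that something is new, unique, unknown or untested is made for them only; others in the source may bear on it.

Compound 1 `COc1ccc(C(=O)/C=C/c2cc(-c3cc(OC)c(OC)c(OC)c3)n[nH]2)cc1OC`: 95%
Compound 2 `COc1ccc(C(=O)/C=C/c2cc(-c3cc(OC)c(OC)c(OC)c3)n[nH]2)cc1`: 97%
Compound 3 `COc1cc(-c2cc(/C=C/C(=O)c3ccc(F)c(F)c3)[nH]n2)cc(OC)c1OC`: 98%

In a functional assay on NCI/ADR-RES cells (Homo sapiens) for cytotoxicity, read by sulforhodamine B assay, with a stated time of 48 h, tested at 0.1 uM (on this read-out higher numbers stand for a weaker effect at the one concentration tested and lower numbers for a stronger effect), compound 1 gives the lowest of the three numbers, but its neighbours sit close: the step of a number 2 percentage points higher from compound 1 to compound 2 (within the scatter) and the step of a number 3 percentage points higher from compound 1 to compound 3 (within the scatter) are both within the scatter, as is a number 1 percentage points higher from compound 2 to compound 3 (within the scatter). Compound 4 `COc1cc(C(=O)/C=C/c2cc(-c3cc(OC)c(OC)c(OC)c3)n[nH]2)cc(OC)c1OC` differs from compound 1 by methoxy in place of hydrogen on an aromatic carbon. The most relevant comparison is a number 2 percentage points higher from compound 1 to compound 2 (within the scatter), which also concerns a methoxy group on an aromatic carbon of the same ring and produced nothing beyond the scatter; the other two steps, changing the whole ring on the carbonyl carbon, were equally flat. No movement beyond the scatter is therefore expected, and the step of no change at the digits printed from compound 1 to compound 4 (within the scatter) is estimated to be small. Compound 4 is expected to give about 95%, in a range from 85% to 104%.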

Compound 4, a percentage reported as activity, at one concentration (the size of the read-out at that concentration, not a potency): 106%
Estimate against measurement, compound 4: 11 percentage points below, outside the stated range (above it).
By their numbers in this assay, from the lowest: compounds 1, 2, 3 and 4 (each within the scatter of the next, the first and the last beyond it).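

Methoxy in place of hydrogen here, ortho to a methoxy group and meta to a large group, gives the only step so far beyond the scatter in this assay: a number 11 percentage points higher from compound 1 to compound 4 (beyond the scatter) and so towards a weaker effect. The step of a number 2 percentage points higher from compound 1 to compound 2 (within the scatter) removes a methoxy from the same ring and stays within the scatter, so this added methoxy matters more on this ring than that removal. Nothing available explains the shift. As far as these compounds go, whether a hydroxyl group or an amine in this place would also weaken the effect remains open. So does what a longer chain such as ethoxy would do.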